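The source may report more compounds than this note shows. Statements on the series, on what has been measured and on what is new or still open speak of the compounds shown alone.

Working notes on the series in a functional assay on MT4 cells (Homo sapiens) for cytotoxicity; on this read-out higher numbers stand for lower toxicity in this test and lower numbers for higher toxicity in this test. Of the compounds shown here, three have numbers so far. Compound 1 `COC(=O)C1C(C)N=C(S)N1Nc1cccc(Cl)c1` gives 190000 nM in this assay. Compound 2 `Cc1nc(S)n(Nc2cccc(Cl)c2)c1-c1ccc(Cl)cc1` gives 40800 nM in this assay. Compound 3 `CSc1nc(C)c(-c2ccccc2)n1Nc1cccc(Cl)c1` gives 42100 nM in this assay. Compound 2 stands at the lowest of the three numbers; the number of compound 3 sits within the usual scatter of it, so no order between compound 2 and compound 3 can be read, while the number of compound 1 lies beyond the scatter above that of compound 2. No pair among these three differs in one place only, so no single-point step is available as a guide.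

Compound 4 `Cc1nc(S)n(Nc2cccc(Cl)c2)c1-c1cccc(Br)c1` is not yet measured. It differs from compound 2 in one place: 3-bromophenyl in place of 4-chlorophenyl on an aromatic carbon. Among the measured compounds shown here, nothing among the measured compounds isolates a change of this kind, so the expectation rests on compound 2 alone. The step from compound 2 to compound 4 in this assay is expected to be a 1.0-fold lower number from compound 2 to compound 4 (0.01 log units; within the scatter), that is, no change beyond the scatter in either direction. For compound 4 the estimate in this assay is 40000 nM, with a range from 15000 nM to 110000 nM.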

Compound 4, half-maximal cytotoxic concentration: 44000 nM
Estimate against measurement, compound 4: 1.1-fold (0.04 log units) below; the measured number falls inside the stated range.
By their numbers in this assay, from the lowest: compounds 2, 3 and 4 (each within the scatter of the next); then compound 1.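

Among the compounds shown here, replacing 4-chlorophenyl with 3-bromophenyl on the aromatic carbon next to the ring nitrogen gives, in this assay, a 1.1-fold higher number from compound 2 to compound 4 (0.03 log units; within the scatter), the first single-point step. At this position, the halogen and its place on the phenyl ring can thus change together without a shift beyond the scatter, although this single step does not separate the two changes. No measured property bears on this result.

A 3-chlorophenyl or 4-bromophenyl group at this carbon would separate the halogen from its place on the phenyl ring. From the compounds shown here alone, it also remains open whether a non-aryl group here, such as an amine, a carboxylic acid or a longer alkyl chain, would move the number in this assay beyond the scatter.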